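Fluoro to chloro exchange across two matched pairs

This account rests on a few compounds, and the source may have more. Where it says the series, first, only, none or still open, it means among the compounds named here.

Measured so far in a functional assay (plasma) for inhibition, with Homo sapiens as the target; on this read-out higher numbers stand for weaker inhibition and lower numbers for stronger inhibition:
compound 1 `O=C(O)CCC/C=C\C[C@@H]1[C@H](O)CC[C@H]1NS(=O)(=O)c1ccc(Cl)cc1` gives 2200 nM
compound 2 `O=C(O)CCC/C=C\C[C@H]1/C(=N/OCC2CCCCC2)CC[C@@H]1NS(=O)(=O)c1ccc(F)cc1` gives 1800 nM
compound 3 `O=C(O)CCC/C=C\C[C@@H]1[C@H](O)CC[C@H]1NS(=O)(=O)c1ccc(F)cc1` gives 6000 nM

Compound 1 and compound 3 share one core and differ in a single place, (chloro in place of fluoro on an aromatic carbon); on this pair the change gives a 2.7-fold lower number from compound 3 to compound 1 (0.44 log units; beyond the scatter). Compound 2 carries a different core; the difference between the two cores is not broken down here. Compound 4 `O=C(O)CCC/C=C\C[C@H]1/C(=N/OCC2CCCCC2)CC[C@@H]1NS(=O)(=O)c1ccc(Cl)cc1`, not yet measured, stands to compound 2 as compound 1 stands to compound 3, by chloro in place of fluoro on an aromatic carbon, at a place described in the same words for both pairs, so it is the same change rather than merely the same kind. A step of similar size is expected for the new pair, a 2.6-fold lower number from compound 2 to compound 4 (0.41 log units; beyond the scatter), because of a 2.7-fold lower number from compound 3 to compound 1 (0.44 log units; beyond the scatter). On that basis compound 4 is estimated at 700 nM in this assay, with a likely range from 300 nM to 1600 nM.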

Compound 4, half-maximal inhibitory concentration: 1700 nM
The estimate for compound 4 lay 2.4-fold (0.39 log units) below the measured number, and the stated range ends below it.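

In this assay, chloro in place of fluoro on the core of compound 2 gives a 1.1-fold lower number from compound 2 to compound 4 (0.02 log units; within the scatter), so this pair alone shows no measurable change. Set side by side, the steps on the two cores cannot be told apart: the same change on two cores in this assay, a 2.7-fold lower number (0.44 log units; beyond the scatter) from compound 3 to compound 1 and a 1.1-fold lower number (0.02 log units; within the scatter) from compound 2 to compound 4, 2.6-fold (0.41 log units) apart, within the scatter of two such steps. The data fit either one shared modest step or a step that depends on the core; with one pair per core, they neither show that the change carries over nor show that it fails to.

Still open, as far as these compounds go, is whether bromo or methyl in the same place would behave alike on both cores. Also open, from the compounds shown here alone, is whether the chloro step would hold with a benzyl group in place of the cyclohexylmethyl group.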